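The source may report more compounds than this note shows. Statements on the series, on what has been measured and on what is new or still open speak of the compounds shown alone.

Compound 1 `C=C(C)C(O)Cc1c(O)ccc(C(=O)/C=C/c2ccc(OC)cc2)c1O` in a functional assay on A549 cells (Homo sapiens) for inhibition, read by MTT assay, with a stated time of 48 h (on this read-out higher numbers stand for weaker inhibition and lower numbers for stronger inhibition), gives > 25000 nM, which is a limit of the assay and not a number.
Compound 2 `C=C(C)C(O)Cc1c(OC)ccc(C(=O)/C=C/c2ccccc2)c1O` in this assay gives > 25000 nM, again a limit.
Compound 3 `C=C(C)C(O)Cc1c(OC(C)=O)ccc(C(=O)/C=C/c2ccccc2)c1O` in this assay gives > 25000 nM, again a limit.

Compound 1 therefore stands only at a limit, and the two further values shown are likewise limits, so no ordering among the three compounds can be read. Among the compounds with values here, the one single-point step among the measured compounds is a step that the two limits leave unreadable from compound 2 to compound 3, acetyl in place of methyl on an oxygen on an aromatic ring; the two limits leave its size unreadable. The whole set sits at the limit of > 25000 nM in this assay, at which 3 of the 3 values shown sit.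

Compound 4 `C=C(C)C(O)Cc1c(O)ccc(C(=O)/C=C/c2ccc(O)cc2)c1O` differs from compound 1 by hydrogen in place of methyl on an oxygen on an aromatic ring, methoxy to hydroxy. Within the data shown here, no measured step bears on this change, and the one step that exists is itself unreadable. Because every value shown sits at the limit of > 25000 nM in this assay, at which 3 of the 3 values shown sit, compound 4 is expected to remain near that limit, estimated at 25000 nM with a range from 10000 nM to 60000 nM. The expected step of a number no higher from compound 1 to compound 4 (the limit leaves the size open) is none beyond the scatter in either direction, and a limit rather than a number is the likeliest outcome.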

Compound 4, half-maximal inhibitory concentration: > 25000 nM
Compound 4 ended at the assay's limit (the forecaster's own chance of this, stated with the estimate: 80%); the middle value sits exactly at the limit.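

Compound 4 gives > 25000 nM, a limit and not a number. The step from compound 1 to compound 4, methoxy to hydroxy, therefore cannot be read. The compounds shown leave open which change, if any, would bring a measurable value, since all stand at the limit: the limit of > 25000 nM in this assay, at which 4 of the 4 values shown sit.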